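From 4-Fluorophenoxy to Butylsulfanyl on a Shared Core

The source may report more compounds than this note shows. Statements on the series, on what has been measured and on what is new or still open speak of the compounds shown alone.

Compound 1 `CCCCSc1cc2[nH]c(C3CCCCC3)nc2cc1NC(=O)OCCC`: 75000 nM
Compound 2 `Cc1ccc(C(=O)Nc2cc3nc(C4CCCCC4)[nH]c3cc2Oc2ccc(F)cc2)cc1`: 26000 nM

In an ADME assay on Vero cells (Chlorocebus sabaeus) for cytotoxicity, read by MTT assay, with a stated time of 2 days (a higher number here means a weaker inhibitor, a lower number a stronger inhibitor), compound 2 gives 26000 nM, the lower of the two numbers and beyond the usual scatter from compound 1. Compound 3 `CCCCSc1cc2[nH]c(C3CCCCC3)nc2cc1NC(=O)c1ccc(C)cc1` keeps the rest of compound 2 but has butylsulfanyl in place of 4-fluorophenoxy on an aromatic carbon. Within the data shown here, no pair of measured compounds differs in just one place, so this change has no direct precedent. Compound 1 also carries butylsulfanyl and gives 75000 nM, which hints at a higher number, although it differs from compound 2 in a second place too. A modest upward move in this assay, perhaps little beyond the scatter, is expected for the step of a 1.7-fold higher number from compound 2 to compound 3 (0.24 log units; within the scatter). The estimate for compound 3 is 45000 nM, with an expected range of 18000 nM to 100000 nM.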

Compound 3, half-maximal inhibitory concentration: > 200000 nM
Compound 3: no number, only a limit; the forecaster's own chance of this, stated with the estimate: 15%; middle value at least 4.4-fold (0.64 log units) from the limit.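

In this assay compound 3 gives > 200000 nM, which is a limit of the assay and not a number. This position now has a direct comparison: butylsulfanyl in place of 4-fluorophenoxy on an aromatic carbon gives an at least 7.6-fold higher number from compound 2 to compound 3 (0.88 log units; beyond the scatter), so the change moves the number upward by more than the usual scatter. With butylsulfanyl kept, 4-methylphenyl in place of propoxy on a carbonyl carbon gives an at least 2.6-fold higher number from compound 1 to compound 3 (0.42 log units; beyond the scatter), and the true size of both steps stays unknown because compound 3 sits at a limit: the limit of > 200000 nM in this assay, at which 1 of the 3 values shown sits.

The compounds shown leave open how far compound 3 lies past that limit. They also leave open whether an amine or a shorter chain such as ethylsulfanyl at this position would give a number that can be read.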